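Thiosemicarbazone series: thiophene replaces chlorophenyl

The source may report more compounds than this note shows. Statements on the series, on what has been measured and on what is new or still open speak of the compounds shown alone.

Compound 1 `CC1=CC[C@H](C(C)(C)NC(=S)NN)CC1` carries the free thiosemicarbazide; in a functional assay on U-251 cells (Homo sapiens) for inhibition, read by sulforhodamine B assay, with a stated time of 48 h (on this read-out lower numbers stand for stronger inhibition of growth and higher numbers for weaker inhibition of growth), compound 1 gives 200 nM. For compound 2 `CC1=CC[C@H](C(C)(C)NC(=S)N/N=C/c2ccc(F)cc2)CC1` the read-out in this assay is a limit, > 100000 nM. Compound 3 `CC1=CC[C@H](C(C)(C)NC(=S)N/N=C/c2ccccc2Cl)CC1` in this assay gives 80600 nM, the highest number among the measured compounds, with compound 1 far below it. Within the data shown here, the only measured step, an at least 1.2-fold lower number from compound 2 to compound 3 (0.09 log units; that floor lies within the scatter), exchanges the ring on the carbon with a double bond to nitrogen and lies within the scatter. Compound 4 `CC1=CC[C@H](C(C)(C)NC(=S)N/N=C/c2cccs2)CC1` differs from compound 3 by thiophen-2-yl in place of 2-chlorophenyl on a carbon with a double bond to nitrogen, once more an exchange of that ring alone. On that basis compound 4 is expected to move by a 1.0-fold lower number from compound 3 to compound 4 (0.00 log units; within the scatter), a step within the scatter. Compound 4 is estimated at 80000 nM in this assay, with a range from 20000 nM to 300000 nM.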

Compound 4, concentration for 50% growth inhibition: 13500 nM
Estimate against measurement, compound 4: 5.9-fold (0.77 log units) above, outside the stated range (below it).
By their numbers in this assay, from the lowest: compound 1; then compound 4; then compound 3. At a limit, above all of these: compound 2.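

In this assay, the ring on the carbon with a double bond to nitrogen now moves the read-out beyond the scatter: thiophen-2-yl in place of 2-chlorophenyl gives a 6.0-fold lower number from compound 3 to compound 4 (0.78 log units; beyond the scatter). Against 4-fluorophenyl the change can be read only as a floor, an at least 7.4-fold lower number from compound 2 to compound 4 (0.86 log units; beyond the scatter), with compound 2 resting on a limit of the assay: the limit of > 100000 nM in this assay, at which 1 of the 4 values shown sits. The free thiosemicarbazide still stays well ahead of the thiophene, with a 68-fold higher number from compound 1 to compound 4 (1.83 log units; beyond the scatter).

Still open, on these data alone, is whether furan-2-yl or cyclohexyl on that carbon narrows this gap to compound 1. Also open, as far as these compounds go, is how an amine or a carboxylic acid on the thiophen-2-yl ring would shift the read-out.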